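Swapping fluorine for chlorine on a second scaffold

The source may report more compounds than this note shows. Statements on the series, on what has been measured and on what is new or still open speak of the compounds shown alone.

Compound 1 `O=C(Nc1nnc(-c2ccc(F)cc2)s1)c1cc(Br)ccc1O` and compound 2 `O=C(Nc1nnc(-c2ccc(Cl)cc2)s1)c1cc(Br)ccc1O` share one core and differ in a single spot: chloro in place of fluoro on an aromatic carbon. In a functional assay on B16-F10 cells (Mus musculus) for antiproliferative activity, read by MTT assay, with a stated time of 48 h (on this read-out lower numbers stand for stronger inhibition and higher numbers for weaker inhibition), compound 1 gives 1020 nM, and compound 2 gives 560 nM. The step of a 1.8-fold lower number from compound 1 to compound 2 (0.26 log units; within the scatter) is therefore small, and the two numbers cannot be told apart with confidence.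

Compound 3 `O=C(Nc1nnc(-c2ccc(F)cc2)s1)c1ccccc1` is built on a different core; how that core differs from the core of compound 1 is not broken down here. In this assay compound 3 gives 4750 nM, the highest of the three measured numbers, beyond the scatter from both compound 1 and compound 2.

Compound 4 `O=C(Nc1nnc(-c2ccc(Cl)cc2)s1)c1ccccc1` carries the same change on the core of compound 3: chloro in place of fluoro on an aromatic carbon. The surroundings of the changed spot read the same in both pairs, so this is the same change. Because the earlier step of a 1.8-fold lower number from compound 1 to compound 2 (0.26 log units; within the scatter) was small, the step from compound 3 to compound 4 is expected to be similar, a 1.8-fold lower number from compound 3 to compound 4 (0.25 log units; within the scatter), in this assay. On that basis compound 4 is estimated at 2700 nM, with a likely range from 1300 nM to 5500 nM.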

Compound 4, half-maximal inhibitory concentration: 4060 nM
Beside the measured number, compound 4's estimate is 1.5-fold (0.18 log units) below it; the measured number falls inside the stated range.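

On the core of compound 3, chloro in place of fluoro gives a 1.2-fold lower number from compound 3 to compound 4 (0.07 log units; within the scatter) in this assay, so once again the swap produces no difference that can be told apart from ordinary repeat variation. Set side by side, the two steps agree: the same change on two cores in this assay, a 1.8-fold lower number (0.26 log units; within the scatter) from compound 1 to compound 2 and a 1.2-fold lower number (0.07 log units; within the scatter) from compound 3 to compound 4, 1.6-fold (0.19 log units) apart, within the scatter of two such steps This shows that, across these two pairs, going from 4-fluorophenyl to 4-chlorophenyl stays a small step on either core, but it does not show that the swap has a real shared effect, or that it has exactly none, and two cores are too few to support a rule for the whole series.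

The compounds shown leave open what other groups in the same place on the aromatic ring, such as methoxy, an amine or a carboxylic acid, would do to the number. They also leave open whether the swap stays this small on a third core.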